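Swapping the Cyclohexylcarbonyl Amide for a Sulfonamide

The compounds below may be only part of what the source reports. "The series", "measured", "known", "first", "only" and "open" are said of these compounds alone.

The three measured compounds share one core and differ only in the group on the amine nitrogen in the ring. Among the compounds with values here, in an assay on HEK293 cells for positive allosteric modulation of metabotropic glutamate receptor 5 (Homo sapiens), read by FLIPR, with a stated time of 1 h (a lower number here means that less compound is needed, a higher number that more compound is needed for the effect), compound 3 `O=C(C1CCCCC1)N1CCc2nc(C#Cc3ccccc3)sc2C1` gives 167 nM, the only number among the three values. Compound 1 `C(#Cc1nc2c(s1)CN(C1CCCCC1)CC2)c1ccccc1` reaches only a limit of this assay, > 10000 nM. Compound 2 `O=C(C1CC1)N1CCc2nc(C#Cc3ccccc3)sc2C1` likewise stops at a limit, > 10000 nM. Within the data shown here, both limits sit at the limit of > 10000 nM in this assay, at which 2 of the 3 values shown sit, so compound 3 stands alone as the sole compound with a readable value. The measured steps are large: an at least 59-fold lower number from compound 1 to compound 3 (1.77 log units; beyond the scatter) and an at least 59-fold lower number from compound 2 to compound 3 (1.77 log units; beyond the scatter), while the step from compound 1 to compound 2 cannot be read between two limits.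

Compound 4 `CC(C)S(=O)(=O)N1CCc2nc(C#Cc3ccccc3)sc2C1` is not yet measured. Its change from compound 3 is isopropylsulfonyl in place of cyclohexylcarbonyl on an amine nitrogen in a ring. The step that bears on it is an at least 59-fold lower number from compound 2 to compound 3 (1.77 log units; beyond the scatter), where shrinking the ring-bearing acyl to a small cyclopropylcarbonyl pushed the number beyond the limit. The isopropylsulfonyl of compound 4 is also small and carries no ring, so a large rise in this assay is expected, possibly back to the limit. Compound 4 is therefore expected to show 4000 nM, between 600 nM and 20000 nM, an expected step of a 24-fold higher number from compound 3 to compound 4 (1.38 log units; beyond the scatter).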

Compound 4, half-maximal effective concentration: > 10000 nM
Compound 4 gave a limit, no number (the forecaster's own chance of this, stated with the estimate: 50%); at least 2.5-fold (0.39 log units) between middle value and limit.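

In this assay, replacing cyclohexylcarbonyl with isopropylsulfonyl on the amine nitrogen in a ring gives an at least 59-fold higher number from compound 3 to compound 4 (1.77 log units; beyond the scatter). Within the data shown here, the earlier compounds carried only a cyclohexyl or a carbonyl-linked group at this position, and compound 4 now shows that a sulfonyl-linked group without a ring also ends at a limit of the assay, leaving compound 3 as the only compound with a readable value: the limit of > 10000 nM in this assay, at which 3 of the 4 values shown sit. The steps linking compound 4 with compound 1 and with compound 2 run between two limits and cannot be read, so nothing can be said about how these three compare.

This change replaces the carbonyl and the cyclohexyl ring in a single step, and the compounds shown do not separate the part played by each; cyclohexylsulfonyl and isopropylcarbonyl on the same nitrogen would divide the change into its separate parts. From the compounds shown here alone, it also remains open whether other acyl groups, such as cyclopentylcarbonyl or benzoyl, would give a readable value at this position.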